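A few compounds are considered here, and "the series" means these few. Any claim that something is new, unique, unknown or untested is made for them only; others in the source may bear on it.

Compound 1 `CS(=O)(=O)NC1CCC(CN2CCN(c3cc(=O)c4cc(C(F)(F)F)cc([N+](=O)[O-])c4s3)CC2)CC1` was tested in an ADME assay on cells (Hepatocyte, Homo sapiens) for metabolic stability; a lower number here means that the compound disappears faster, a higher number that the compound lasts longer. In this assay compound 1 returns only a limit of the assay, > 1.55 h, so its place among the measured compounds is known as a limit alone (the limit of > 1.55 h in this assay, at which 1 of the 3 values shown sits). Compound 2 `O=C(OC1CCC(CN2CCN(c3cc(=O)c4cc(C(F)(F)F)cc([N+](=O)[O-])c4s3)CC2)CC1)c1ccc(F)cc1` gives 0.0983 h, and compound 3 `O=C(OC1CCC(CN2CCN(c3cc(=O)c4cc(C(F)(F)F)cc([N+](=O)[O-])c4s3)CC2)CC1)c1cccs1` gives 0.0917 h, with a 1.1-fold lower number from compound 2 to compound 3 (0.03 log units; within the scatter). The changes that bear on the new compound are the two at the same saturated ring carbon, an at least 15-fold lower number from compound 1 to compound 2 (1.19 log units; beyond the scatter) and an at least 16-fold lower number from compound 1 to compound 3 (1.22 log units; beyond the scatter). Compound 4 `O=C(NC1CCC(CN2CCN(c3cc(=O)c4cc(C(F)(F)F)cc([N+](=O)[O-])c4s3)CC2)CC1)c1ccccc1` differs from compound 1 by benzoyl in place of methylsulfonyl on an amine nitrogen. Compound 4 carries benzamido rather than an ester, and its step is expected to be smaller than an at least 15-fold lower number from compound 1 to compound 2 (1.19 log units; beyond the scatter). The step to compound 4 is expected to be an at least 2.5-fold lower number from compound 1 to compound 4 (0.41 log units; beyond the scatter). Compound 4 is therefore estimated at 0.6 h, in the range 0.15 h to 1.8 h.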

Compound 4, half-life: > 1.55 h
Compound 4 ended at the assay's limit (the forecaster's own chance of this, stated with the estimate: 20%); middle value at least 2.5-fold (0.41 log units) from the limit.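

In this assay compound 4 stands at a limit of the assay: the limit of > 1.55 h in this assay, at which 2 of the 4 values shown sit.

With benzamido on the saturated ring carbon, the number lies far from those of the esters, an at least 16-fold higher number from compound 3 to compound 4 (1.22 log units; beyond the scatter) and an at least 15-fold higher number from compound 2 to compound 4 (1.19 log units; beyond the scatter), so among these compounds a benzoyl group on the amine nitrogen does not bring the low numbers that the two aryl esters show. The step between compound 1 and compound 4 cannot be read, since both values are limits.

Which of compound 1 and compound 4 lasts longer stays open. So does how a urea or a carbamate at this position would behave.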